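The compounds below may be only part of what the source reports. "The series", "measured", "known", "first", "only" and "open" are said of these compounds alone.

Compound 1 `CC(C)C(NS(=O)(=O)c1cccc(Br)c1)C1=CC(=O)c2c(O)ccc(O)c2C1=O`: 790 nM
Compound 2 `CC(C)C(NS(=O)(=O)c1ccccc1Br)C1=CC(=O)c2c(O)ccc(O)c2C1=O`: 340 nM
Compound 3 `CCOC(=O)c1ccc(S(=O)(=O)NC(C2=CC(=O)c3c(O)ccc(O)c3C2=O)C(C)C)cc1`: 150 nM

In a functional assay on HL-60 cells (Homo sapiens) for cytotoxicity, read by MTT assay (a higher number here means a weaker inhibitor, a lower number a stronger inhibitor), compound 1 gives 790 nM as the highest of these numbers. It is therefore the weakest of the three, as both of its steps to the others lie beyond the scatter.

Compound 4 `CC(NS(=O)(=O)c1cccc(Br)c1)C1=CC(=O)c2c(O)ccc(O)c2C1=O` has not been measured yet. It keeps the 3-bromophenyl on the sulfonyl sulfur of compound 1 but changes a different group: methyl in place of isopropyl on a saturated chain carbon bound to a double-bonded ring carbon and a sulfonamide nitrogen. In words, this is methyl in place of isopropyl on a saturated chain carbon bound to a double-bonded ring carbon and a sulfonamide nitrogen.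

Among the measured compounds shown here, no measured compound changes that group. All three carry isopropyl, and their steps only swap the group on the sulfonyl sulfur: a 2.3-fold lower number from compound 1 to compound 2 (0.37 log units; beyond the scatter), a 2.3-fold lower number from compound 2 to compound 3 (0.36 log units; beyond the scatter) and a 5.3-fold lower number from compound 1 to compound 3 (0.72 log units; beyond the scatter). These modest steps give no direction for the new change. They show only how far one swap has moved the number in this small set. In this assay a step of similar modest size at most is therefore expected, in either direction, and it may not exceed the scatter.

The estimated step is a 1.1-fold lower number from compound 1 to compound 4 (0.05 log units; within the scatter), with little weight on its direction. For compound 4 the estimated value is 700 nM, with an expected range from 250 nM to 2000 nM as its likely span.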

Compound 4, half-maximal inhibitory concentration: 160 nM
Compound 4: the middle estimate sits 4.4-fold (0.64 log units) above what was measured; measured number below the stated range.
By their numbers in this assay, from the lowest: compounds 3 and 4 (each within the scatter of the next); then compound 2; then compound 1.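

In this assay the saturated chain carbon bound to a double-bonded ring carbon and a sulfonamide nitrogen proves to be a place where the number can move: methyl, with 1 heavy atom, in place of isopropyl, with 3, gives a 4.9-fold lower number from compound 1 to compound 4 (0.69 log units; beyond the scatter). Until now only the group on the sulfonyl sulfur had been seen to change the number, and this new step is modest in the same way as the swap that gave a 5.3-fold lower number from compound 1 to compound 3 (0.72 log units; beyond the scatter), so the chain carbon cannot be treated as a passive part of the series. Nothing available explains why the change at this place lowers the number.

The compounds shown leave open whether methyl would lower the number by a similar amount alongside the 2-bromophenyl of compound 2 or the 4-(ethoxycarbonyl)phenyl of compound 3, since here its effect can be read only with 3-bromophenyl on the sulfonyl sulfur. They also leave open how an ethyl group, a longer chain such as n-butyl, or a hydroxymethyl group at the same carbon would behave, so two groups at one place do not yet give a trend.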